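Dipropylamino in Place of Benzylamino on a Quinone Core

The source may hold more compounds than are shown below. What is called first, only, known or untested is meant among the compounds shown, and "the series" means these compounds.

Measured so far:
Compound 1, `O=C1C=C(NCc2ccccc2)C(=O)c2c1nc1n2[C@H]2OC[C@@H](O)[C@H]2OC1`, in a functional assay on ECa-109 cells for inhibition, with ECa-109 cell line (Homo sapiens) as the target, read by sulforhodamine B assay (on this read-out higher numbers stand for weaker inhibition and lower numbers for stronger inhibition), gives > 8000 nM.
Compound 2, `CCOc1ccc(NC2=CC(=O)c3c(nc4n3[C@H]3OC[C@@H](O)[C@H]3OC4)C2=O)cc1`, in this assay gives > 4000 nM.

Both of these numbers are limits of the assay, not measured values. Compound 1 sits at the limit of > 8000 nM in this assay, at which 1 of the 2 values shown sits. Compound 2 sits at the limit of > 4000 nM in this assay, at which 1 of the 2 values shown sits. So compound 1 stands only at a limit, and the one other value shown is a limit as well; neither compound can be placed above or below the other, and nothing shows how any structural change moves this read-out.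

The unmeasured compound 3, `CCCN(CCC)C1=CC(=O)c2nc3n(c2C1=O)[C@H]1OC[C@@H](O)[C@H]1OC3`, differs from compound 1 in one place: dipropylamino in place of benzylamino on a double-bonded ring carbon. Among the compounds with values here, no step between measured compounds exists here, so the size of the change to expect in this assay rests on nothing but the two limits. With compound 1 at a limit, the step that the limit leaves unreadable from compound 1 to compound 3 is expected to be small, with no direction resolvable beyond the scatter. Compound 3 is therefore expected to give about 12000 nM, between 3000 nM and 50000 nM, most likely reported again as a limit.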

Compound 3, half-maximal inhibitory concentration: > 16000 nM
Compound 3 was reported as a limit; the forecaster's own chance of this, stated with the estimate: 70%; middle value at least 1.3-fold (0.12 log units) away from the limit.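

In this assay compound 3 gives > 16000 nM, which is a limit of the assay. Compound 1 also stands only at a limit, so the step between compound 1 and compound 3 cannot be read. The compounds shown leave open how strongly each one inhibits, and whether dipropylamino in place of benzylamino changes the read-out at all.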